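Pyrazole in place of fluorophenyl: kinetic solubility outlook

The source may hold more compounds than are shown below. What is called first, only, known or untested is meant among the compounds shown, and "the series" means these compounds.

Compound 1 `Cc1cc(Nc2ccccn2)n2nc(C)c(-c3ccccc3)c2n1` — < 5000 nM
Compound 2 `Cc1cc(NCc2ccccn2)n2ncc(-c3ccccc3F)c2n1` — 5000 nM

In a physicochemical assay for solubility, read by HPLC, using the shake flask method, measured as kinetic solubility, with a stated time of 2 h, at pH 7.4 (on this read-out higher numbers stand for higher solubility and lower numbers for lower solubility), compound 1 gives < 5000 nM, which is a limit of the assay and not a number. Compound 1 therefore sits at the limit of < 5000 nM in this assay, at which 1 of the 2 values shown sits. Among the compounds with values here, compound 2 gives 5000 nM in this assay, the only full number among the measured compounds. Compound 3 `Cc1cc(NCc2ccccn2)n2ncc(-c3ccn(C)n3)c2n1` is not yet measured; it differs from compound 2 by 1-methyl-1H-pyrazol-3-yl in place of 2-fluorophenyl on an aromatic carbon. Within the data shown here, no measured step links any two compounds here, so the expectation rests on the change alone: a step toward higher solubility beyond the usual scatter, a 3.0-fold higher number from compound 2 to compound 3 (0.48 log units; beyond the scatter), is expected. Compound 3 is estimated at 15000 nM, within 5000 nM to 50000 nM.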

Compound 3, solubility: 188000 nM
Estimate against measurement, compound 3: 13-fold (1.10 log units) below; measured number above the stated range.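

In this assay, within the data shown here, 1-methyl-1H-pyrazol-3-yl in place of 2-fluorophenyl on an aromatic carbon gives a 38-fold higher number from compound 2 to compound 3 (1.58 log units; beyond the scatter), the only measured step at this position, and a large one. It shows that the read-out can move far with the ring held at this place alone. Nothing shown tells which part of the change carries the step, since ring size and hetero atoms change together.

Going by these compounds, how an unsubstituted pyrazole, a pyridine or a morpholine would read at this position stays open. So does whether the step would hold on the core of compound 1.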